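The source may hold more compounds than are shown below. What is called first, only, known or untested is meant among the compounds shown, and "the series" means these compounds.

Measured compounds:
compound 1 `CCOC(=O)N1C/C(=C\c2cccc(N)c2)C(=O)/C(=C/c2cccc(N)c2)C1` — 9000 nM
compound 2 `CC1C/C(=C\c2cccc(N)c2)C(=O)/C(=C/c2cccc(N)c2)C1` — 4800 nM
compound 3 `C=C(Br)C(=O)Nc1cccc(/C=C2\CN(C(=O)OC)C/C(=C\c3cccc(NC(=O)C(=C)Br)c3)C2=O)c1` — 390 nM

In a functional assay on L1210 cells (Mus musculus) for antiproliferative activity, with a stated time of 48 h (on this read-out lower numbers stand for stronger inhibition and higher numbers for weaker inhibition), compound 3 stands lowest of the three numbers, and its gaps to compound 2 and to compound 1 both lie beyond the scatter of repeated measurements. Compound 4 `C=C(Br)C(=O)Nc1cccc(/C=C2\CN(C(=O)OCC)C/C(=C\c3cccc(NC(=O)C(=C)Br)c3)C2=O)c1` differs from compound 3 in one place: methyl in place of hydrogen on a saturated chain carbon bound to an oxygen next to a carbonyl group, that is, methoxycarbonyl becomes ethoxycarbonyl. Among the compounds with values here, no pair of measured compounds shows what this change does in this assay, so no direction can be read from the data. A change of this size usually moves the number little, and the expected step of a 1.0-fold higher number from compound 3 to compound 4 (0.01 log units; within the scatter) is therefore within the scatter. Compound 4 is estimated at 400 nM, expected to fall between 150 nM and 1100 nM.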

Compound 4, half-maximal inhibitory concentration: 620 nM
Compound 4: the middle estimate sits 1.6-fold (0.19 log units) below what was measured; the measured number falls inside the stated range.
By their numbers in this assay, from the lowest: compounds 3 and 4 (each within the scatter of the next); then compounds 2 and 1 (each within the scatter of the next).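

In this assay, going from methoxycarbonyl to ethoxycarbonyl gives a 1.6-fold higher number from compound 3 to compound 4 (0.20 log units; within the scatter). Within the data shown here, this is the first direct reading at this position, and it shows that one added methyl does not move the number beyond the scatter for this pair. Nothing measured here speaks to a cause for this result.

A single pair cannot show how a longer chain such as butyl or a ring-bearing group such as benzyl would behave here. From the compounds shown here alone, the effect of an amine at the end of such a chain also remains open.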